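Swapping One Group on Compound 2

The source may hold more compounds than are shown below. What is called first, only, known or untested is meant among the compounds shown, and "the series" means these compounds.

Compound 1 `CCC(c1nc2ncc(Cl)cc2[nH]1)[C@H]1CC[C@@H](c2ccnc3ccc(C(F)(F)F)cc32)CC1`: 81%
Compound 2 `CCC(c1nc2ccc(Cl)cc2[nH]1)[C@H]1CC[C@@H](c2ccnc3ccc(F)cc32)CC1`: 27%

In an ADME assay on microsomes from liver (Rattus norvegicus) for metabolic stability, with a stated time of 10 min, tested at 0.5 uM (a higher number here means that more of the compound is left, a lower number that less of the compound is left), compound 2 stands at 27%, the lower of the two numbers, and compound 1 stands at 81%, a gap beyond the usual scatter. Compound 3 `CCC(c1nc2ncc(Cl)cc2[nH]1)[C@H]1CC[C@@H](c2ccnc3ccc(F)cc32)CC1` has not yet been measured. It comes from compound 2 by a single change: a group of 10 heavy atoms (6 carbon, 3 nitrogen, 1 chlorine; one five-membered aromatic ring with 2 hetero atoms, one six-membered aromatic ring with 1 hetero atom) in place of a group of 10 heavy atoms (7 carbon, 2 nitrogen, 1 chlorine; one five-membered aromatic ring with 2 hetero atoms, one six-membered aromatic ring of carbon only), on a saturated chain carbon bound to a saturated chain carbon and a saturated ring carbon. The change lies on a saturated chain carbon bound to a saturated chain carbon and a saturated ring carbon. Within the data shown here, no measured pair shows this change alone. Compound 1 carries the entering group and reaches 81%, but it also differs from compound 2 elsewhere, so only part of that gap is expected to carry over. The expected change in this assay is upward and beyond the scatter, estimated as a number 25 percentage points higher from compound 2 to compound 3 (beyond the scatter). For compound 3 the estimated value is 52%, with an expected range from 32% to 72%.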

Compound 3, percent of the compound remaining: 35%
The estimate for compound 3 lay 17 percentage points above the measured number; the range from low to high includes it.
By their numbers in this assay, from the lowest: compounds 2 and 3 (each within the scatter of the next); then compound 1.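

In this assay, placing the group with one hetero atom in its six-membered ring where 6-chloro-1H-benzimidazol-2-yl stood, on a saturated chain carbon bound to a saturated chain carbon and a saturated ring carbon, gives a number 8 percentage points higher from compound 2 to compound 3 (within the scatter), so this change alone does not separate the two compounds. Fluoro in place of trifluoromethyl on an aromatic carbon gives a number 46 percentage points lower from compound 1 to compound 3 (beyond the scatter), so among these compounds the large gap goes with that aromatic carbon and not with the chain-carbon substituent. Nothing available here explains the size of either step.

As far as these compounds go, whether trifluoromethyl would give a comparable step alongside 6-chloro-1H-benzimidazol-2-yl remains open. Also open, from the compounds shown here alone, is where a nitrile or a methoxy group on that aromatic carbon would fall in this assay relative to fluoro and trifluoromethyl.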